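A few compounds are considered here, and "the series" means these few. Any claim that something is new, unique, unknown or untested is made for them only; others in the source may bear on it.

The series is built on a shared core carrying a substituted benzyl or aryloxyethyl group on its oxygen. Compound 1, `Brc1ccc(OCCOc2nc3ccccc3s2)c(Br)c1`, is the compound with the largest response so far: in a functional assay on the whole organism with Mus musculus as the target, in the writhing test, at a dose of 100 mg/kg by the intraperitoneal route (a higher number here means more inhibition at the dose given (going by the name of the read-out), a lower number less inhibition), compound 1 gives 68.6%. Compound 3, `Fc1ccccc1COc1nc2ccccc2s1`, also has a number, and in this assay compound 3 gives 51.9%. Compound 2, `Cc1ccc(COc2nc3ccccc3s2)cc1`, stands apart from these two: in this assay compound 2 is reported as "not active" (no number reported) with no number, so no single figure can be placed beside the values of compound 1 and compound 3.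

The step under consideration leads from compound 2 to compound 4, `O=[N+]([O-])c1ccc(COc2nc3ccccc3s2)cc1`. The change is nitro in place of methyl on an aromatic carbon. Among the measured compounds shown here, no measured pair in this set shares that change, so its size in this assay cannot be read from a neighbouring step. With compound 2 reported as not active, the step is expected to go upward, likely beyond the scatter, yet the two compounds with numbers do not share the change and offer no direct guide to how far it reaches.

On that footing the inhibition expected for compound 4 in this assay is 30%, with a range from 5% to 55%, and the chance remains that it too is reported only as not active.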

Compound 4, a percentage reported as inhibition, in the whole organism at one dose (the size of the read-out at that dose, not a potency): 97%
Compound 4: middle estimate off by 67 percentage points, on the low side, outside the stated range (above it).
By their numbers in this assay, from the lowest: compound 3; then compound 1; then compound 4.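

Compound 2 has no number in this assay and its step to compound 4 cannot be read, although compound 4 gives 97% there. The compounds shown leave open how much of the response of compound 4 goes with the nitro group itself, as no two compounds with numbers differ in one place. No measurement shown here bears on the cause of this result.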